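Chain-branching at the hydroxyalkyl amide tail of a lipopeptide series

This account rests on a few compounds, and the source may have more. Where it says the series, first, only, none or still open, it means among the compounds named here.

Measured so far:
compound 1, `CCCCCCCCCCCC(=O)OC[C@H](CSC[C@@H](N)C(=O)NC(C)(C)CO)OC(=O)CCCCCCCCCCC`, 15500 nM
compound 2, `CCCCCCCCCCCC(=O)OC[C@H](CSC[C@@H](N)C(=O)N[C@@H](C)CO)OC(=O)CCCCCCCCCCC`, 1560 nM
compound 3, `CCCCCCCCCCCC(=O)OC[C@H](CSC[C@@H](N)C(=O)NCCCCCCO)OC(=O)CCCCCCCCCCC`, 33 nM

In an assay on HEK293 cells for agonist activity at Toll-like receptor 2 (Homo sapiens) (on this read-out lower numbers stand for an effect already at smaller amounts and higher numbers for an effect only at larger amounts of compound), compound 3 gives the lowest number of the three, with the step to compound 2 and the step to compound 1 both beyond the scatter. Compound 4 is `CCCCCCCCCCCC(=O)OC[C@H](CSC[C@@H](N)C(=O)NCCCC(C)(C)CO)OC(=O)CCCCCCCCCCC`; the change reads (1-(hydroxymethyl)-1-methylethyl in place of 3-hydroxypropyl on a saturated chain carbon, three bonds along the chain from an amide-type nitrogen). The measured steps bearing on it are a 470-fold lower number from compound 1 to compound 3 (2.67 log units; beyond the scatter) and a 9.9-fold lower number from compound 1 to compound 2 (1.00 log units; beyond the scatter), where the same branched group sat directly on the amide-type nitrogen. Since in compound 4 the branching sits further out along the chain, a smaller shift in this assay is expected, in the direction of a higher number: estimated a 6.1-fold higher number from compound 3 to compound 4 (0.78 log units; beyond the scatter). For compound 4 the expected value is 200 nM, range 40 nM to 1500 nM.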

Compound 4, half-maximal effective concentration: 30700 nM
Estimate against measurement, compound 4: 150-fold (2.19 log units) below, and the stated range ends below it.
By their numbers in this assay, from the lowest: compound 3; then compound 2; then compounds 1 and 4 (each within the scatter of the next).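

In this assay, the 1-(hydroxymethyl)-1-methylethyl group in place of 3-hydroxypropyl on a saturated chain carbon, three bonds along the chain from an amide-type nitrogen, gives a 930-fold higher number from compound 3 to compound 4 (2.97 log units; beyond the scatter), so branching further out brings no relief here. Against the short branched tails, the 4-(hydroxymethyl)-4-methylpentyl tail gives a 2.0-fold higher number from compound 1 to compound 4 (0.30 log units; within the scatter) and a 20-fold higher number from compound 2 to compound 4 (1.29 log units; beyond the scatter), so chain length alone does not carry the low number of compound 3. Nothing available explains this result. Open, going by these compounds, is whether a single methyl branch at that place already gives the full step, and whether an amine in place of the hydroxyl or a longer unbranched chain keeps the low number.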